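Chain extension from compound 3 to compound 4

The source may hold more compounds than are shown below. What is called first, only, known or untested is meant among the compounds shown, and "the series" means these compounds.

Compound 1 `CC1=C(SCCC(=O)OC(C[Se]c2ccccc2)C(=O)NCCCCCC(=O)OCc2ccccc2)C(=O)c2ccccc2C1=O` was tested in a functional assay on A-431 cells (Homo sapiens) for cytotoxicity, read by MTT assay, with a stated time of 24 h; on this read-out higher numbers stand for weaker inhibition and lower numbers for stronger inhibition. In this assay compound 1 gives only a limit, > 100000 nM. Compound 2 `CC1=C(SCCC(=O)OC(CC[Se]c2ccccc2)C(=O)NCCCCCC(=O)OCc2ccccc2)C(=O)c2ccccc2C1=O` carries a group of 8 heavy atoms (7 carbon, 1 selenium; one six-membered aromatic ring of carbon only) in place of a group of 7 heavy atoms (6 carbon, 1 selenium; one six-membered aromatic ring of carbon only), on a saturated chain carbon, two bonds along the chain from a carbonyl carbon and an oxygen next to a carbonyl group. In this assay compound 2 likewise gives only a limit, > 100000 nM. The step that the two limits leave unreadable from compound 1 to compound 2 cannot be read because both values sit at the limit of > 100000 nM in this assay, at which 2 of the 3 values shown sit.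

Going by the values given here, compound 3 `CC1=C(SCCC(=O)OC(C[Se]c2ccccc2)C(=O)NC(C)(C)C)C(=O)c2ccccc2C1=O` is the only member with a number: in this assay compound 3 gives 7000 nM. The difference between the core of compound 3 and the core of compound 1 is not broken down here.

Compound 4 `CC1=C(SCCC(=O)OC(CC[Se]c2ccccc2)C(=O)NC(C)(C)C)C(=O)c2ccccc2C1=O` has not been measured. It carries a group of 8 heavy atoms (7 carbon, 1 selenium; one six-membered aromatic ring of carbon only) in place of a group of 7 heavy atoms (6 carbon, 1 selenium; one six-membered aromatic ring of carbon only), on a saturated chain carbon, two bonds along the chain from a carbonyl carbon and an oxygen next to a carbonyl group, the same change that separates compound 1 from compound 2. Since that earlier step gave no readable size, the expectation for compound 4 rests on compound 3 alone, with its value 7000 nM as the anchor and a step of a 1.1-fold higher number from compound 3 to compound 4 (0.06 log units; within the scatter) expected to stay within the scatter. Compound 4 is therefore estimated at 8000 nM in this assay, with a range from 3000 nM to 25000 nM.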

Compound 4, half-maximal inhibitory concentration: > 100000 nM
Compound 4: a limit, no number; the forecaster's own chance of this, stated with the estimate: 5%; middle value at least 12-fold (1.09 log units) away from the limit.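

In this assay, putting the group of 8 heavy atoms in place of the group of 7 heavy atoms on the core of compound 3 gives an at least 14-fold higher number from compound 3 to compound 4 (1.15 log units; beyond the scatter), so on this core the change is not neutral. For compound 4, > 100000 nM is a limit of the assay and not a number, so the step has a lower bound but no exact size. The same change on the core of compound 1 cannot be read, so the data do not show whether the step carries from one core to the other: the limit of > 100000 nM in this assay, at which 3 of the 4 values shown sit.

The compounds shown leave open whether a still longer chain in the same place would keep the value of compound 4 at its limit, or whether sulfur in place of selenium would restore a measurable value. They also leave open how an amine or a carboxylic acid on the phenyl ring would behave on either core.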